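Taking One Methoxy from the Lowest Compound

A few compounds are considered here, and "the series" means these few. Any claim that something is new, unique, unknown or untested is made for them only; others in the source may bear on it.

In an ADME assay on microsomes from liver (Rattus norvegicus) for metabolic stability, with a stated time of 10 min (a lower number here means that less of the compound is left, a higher number that more of the compound is left), compound 1 `COc1nn2cc(-c3cc4ccc(OC)c(OC)c4o3)nc2s1` stands lowest of the three measured compounds, with 3% left. Compound 2 `CCSc1nn2cc(-c3cc4ccccc4o3)nc2s1` has 35% left and compound 3 `COc1cc(OCc2cccc(Sc3ccccc3)c2)c2cc(-c3cn4nc(OC)sc4n3)oc2c1` has 45% left, both beyond the scatter from compound 1. Compound 4 `COc1nn2cc(-c3cc4cccc(OC)c4o3)nc2s1` is still unmeasured. It departs from compound 1 in one place: hydrogen in place of methoxy on an aromatic carbon with hydrogen in place of methoxy on an aromatic carbon. Going by the values given here, no measured pair shows this change alone. Compound 2, with no methoxy on its six-membered carbon ring, has 35% left, although compound 3 carries methoxy there and reads higher. A moderate rise is therefore expected, an estimated a number 12 percentage points higher from compound 1 to compound 4 (beyond the scatter) in this assay and only slightly beyond the scatter. For compound 4 the estimate is 15% left, with an expected range from 4% to 38% across repeat measurements.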

Compound 4, percent of the compound remaining: 11%
Compound 4: middle estimate off by 4 percentage points, on the high side; measured number inside the range.
By their numbers in this assay, from the lowest: compounds 1 and 4 (each within the scatter of the next); then compounds 2 and 3 (each within the scatter of the next).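

In this assay, the change alone, hydrogen in place of methoxy on an aromatic carbon ortho to a methoxy group, gives a number 8 percentage points higher from compound 1 to compound 4 (within the scatter) and so no separation between the two compounds. At this position, the methoxy of compound 1 can therefore be exchanged for hydrogen without a reading that stands apart from the scatter. Nothing at hand explains this result.

From the compounds shown here alone, whether an amine or an ethoxy group on this carbon would read differently remains open. So does the reading with hydrogen in place of the remaining methoxy of compound 4.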